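The source may report more compounds than this note shows. Statements on the series, on what has been measured and on what is new or still open speak of the compounds shown alone.

Measured compounds:
compound 1 `O=c1cc(NC2CC2)cc(-c2ccccc2)o1` in a functional assay on KBVIN cells (Homo sapiens) for cytotoxicity, read by MTT assay, with a stated time of 72 h; on this read-out lower numbers stand for an effect already at smaller amounts and higher numbers for an effect only at larger amounts of compound: > 30 uM
compound 2 `COc1ccc(Nc2cc(-c3ccccc3)oc(=O)c2)cc1` in this assay: 0.098 uM

Compound 1 sits at the limit of > 30 uM in this assay, at which 1 of the 2 values shown sits, which is a limit of the assay and not a number. For the measured compounds named here, compound 2 therefore stands as the only number on this read-out. Compound 3 `O=c1cc(Nc2ccc(Br)cc2)cc(-c2ccccc2)o1` carries bromo in place of methoxy on an aromatic carbon, bromo in place of methoxy on an aromatic carbon. Going by the values given here, no measured pair shows such a swap, so its size is open; a step within the usual scatter, or a small shift in either direction, seems most plausible. Compound 3 is expected to give about 0.15 uM, between 0.03 uM and 0.8 uM, meaning an expected step of a 1.5-fold higher number from compound 2 to compound 3 (0.18 log units; within the scatter).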

Compound 3, concentration for half-maximal effect: 0.24 uM
Compound 3: middle estimate off by 1.6-fold (0.20 log units), on the low side; low and high end bracket the measured number.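

Swapping methoxy for bromo on this aromatic carbon gives a 2.4-fold higher number from compound 2 to compound 3 (0.39 log units; beyond the scatter), so in this assay the number stays low without methoxy, though it does rise modestly. Replacing cyclopropyl on the nitrogen with 4-bromophenyl gives an at least 120-fold lower number from compound 1 to compound 3 (2.09 log units; beyond the scatter), which shows that a substituted phenyl ring here can go with a far lower number. That step is only a lower bound, since compound 1 has a limit of the assay and not a number: the limit of > 30 uM in this assay, at which 1 of the 3 values shown sits.

On these data alone, it remains open whether a hydrogen, a fluoro or an amine at this carbon would keep the number as low. The effect of moving bromo elsewhere on the ring is also unknown.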